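A few compounds are considered here, and "the series" means these few. Any claim that something is new, unique, unknown or untested is made for them only; others in the source may bear on it.

a functional assay on CCRF-CEM cells for antagonist activity at C-X-C chemokine receptor type 4 (Homo sapiens), read by calcium flux, with stated times of 25 min and 90 s (on this read-out higher numbers stand for weaker inhibition and lower numbers for stronger inhibition), has so far been run on two compounds. Compound 1 `C/C(=C/CN(C[C@H]1Cc2ccccc2CN1)[C@H]1CCCc2cccnc21)CN` gives 8.6 nM there, and compound 2 `NC[C@H]1CC[C@H](CN(C[C@H]2Cc3ccccc3CN2)[C@H]2CCCc3cccnc32)CC1` gives 340 nM, the higher of the two numbers, reached by a 40-fold higher number from compound 1 to compound 2 (1.60 log units; beyond the scatter). Compound 3 `C/C(CN(C[C@H]1Cc2ccccc2CN1)[C@H]1CCCc2cccnc21)=C(\F)CN` carries 3-amino-2-fluoro-1-methylprop-1-en-1-yl in place of 4-(aminomethyl)cyclohexyl on a saturated chain carbon bound to an amine nitrogen. The entering chain matches that of compound 1 apart from its added fluorine, and the change largely reverses a 40-fold higher number from compound 1 to compound 2 (1.60 log units; beyond the scatter), so the expected step of a 28-fold lower number from compound 2 to compound 3 (1.45 log units; beyond the scatter) is a large fall in this assay. Compound 3 is therefore estimated at 12 nM, with a likely range from 3 nM to 50 nM.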

Compound 3, half-maximal inhibitory concentration: 80 nM
The estimate for compound 3 lay 6.7-fold (0.82 log units) below the measured number; measured number above the stated range.
By their numbers in this assay, from the lowest: compound 1; then compound 3; then compound 2.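

In this assay, the open fluorinated chain recovers only part of what the 4-(aminomethyl)cyclohexyl group lost, with a 4.3-fold lower number from compound 2 to compound 3 (0.63 log units; beyond the scatter) as the gain. It does not match the chain of compound 1, and a 9.3-fold higher number from compound 1 to compound 3 (0.97 log units; beyond the scatter) shows the cost, so this position distinguishes between two similar open chains, which carry the methyl on different carbons and differ by the fluorine. No supporting measurement accounts for this difference. From the compounds shown here alone, whether the fluorine or the shifted methyl drives the loss remains open. So does how a chlorine in place of the fluorine, or a longer chain, would read.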